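Methyl in Place of Methoxy: From Compound 1 to Compound 4

This account rests on a few compounds, and the source may have more. Where it says the series, first, only, none or still open, it means among the compounds named here.

Compound 1 `COc1cccc2c1OCN(c1ccc3oc(-c4ccccc4)cc(=O)c3c1)C2` gives 91.9%.
Compound 2 `Cc1cc(C)c2c(c1)CN(c1ccc3c(=O)cc(-c4ccccc4)oc3c1)CO2` gives 48.4%.
Compound 3 `O=c1cc(-c2ccccc2)oc2ccc(N3COc4c(Br)cc(Br)cc4C3)cc12` gives 34.5%.

In a functional assay on MCF7 cells (Homo sapiens) for inhibition, read by MTT assay, with a stated time of 48 h, tested at 60 ug/mL (on this read-out higher numbers stand for more inhibition of growth at the one concentration tested and lower numbers for less inhibition of growth), compound 1 stands highest of the three numbers. Compound 2 lies lower by a gap beyond the scatter, and compound 3 lies lower still, also beyond the scatter. Compound 4 `Cc1cccc2c1OCN(c1ccc3oc(-c4ccccc4)cc(=O)c3c1)C2` has not yet been measured. It differs from compound 1 by methyl in place of methoxy on an aromatic carbon. For the measured compounds named here, no two measured compounds differ from each other in a single place, so there is no directly comparable step to lean on; compounds 2 and 3 each carry two substituents on that part of the core, and their lower numbers cannot be tied to one change. The change from compound 1 is small in size, a single heavy atom less and one acceptor fewer, and the account therefore anticipates only a modest downward movement, possibly none beyond the scatter. Compound 4 is expected to give about 80%, with a range from 55% to 95%. This corresponds to an expected step of a number 11.9 percentage points lower from compound 1 to compound 4 (beyond the scatter).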

Compound 4, percent growth inhibition at one concentration: 85.1%
Compound 4: middle estimate off by 5.1 percentage points, on the low side, within the range that was stated.
By their numbers in this assay, from the lowest: compound 3; then compound 2; then compounds 4 and 1 (each within the scatter of the next).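

In this assay, for the compounds shown here, methyl in place of methoxy on an aromatic carbon gives a number 6.8 percentage points lower from compound 1 to compound 4 (within the scatter) and is the first step in this set that can be read at a single place. At this position, the methoxy with its hydrogen-bond acceptor can thus give way to methyl without a difference that can be told from the scatter, so compound 1 and compound 4 cannot be separated on this read-out. Nothing shown gives a reason for this result.

As far as these compounds go, whether the tolerance extends to an amine, a carboxylic acid or a longer chain such as ethoxy at this position remains open. Also open is which substituent accounts for the lower numbers of compound 2 and compound 3, each of which carries two on that part of the core.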